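Cyclobutyl Replacing Hydroxycyclohexyl: What Stability to Expect

The source may report more compounds than this note shows. Statements on the series, on what has been measured and on what is new or still open speak of the compounds shown alone.

Measured so far:
compound 1 `Nc1ncnc2c1c(Oc1cc(C(F)(F)F)ccn1)nn2[C@@H]1CCCC[C@H]1O`: > 2.41 h
compound 2 `N#Cc1ccnc(Oc2nn([C@H]3C[C@H](O)C3)c3ncnc(N)c23)c1`: > 2.41 h

In an ADME assay on microsomes from liver (Homo sapiens) for metabolic stability, read by LC-MS, using NADPH, with a stated time of 10 min, tested at 10 uM (a higher number here means that the compound lasts longer, a lower number that the compound disappears faster), compound 1 gives > 2.41 h, which is a limit of the assay and not a number. Compound 2 likewise gives > 2.41 h, again a limit. For the measured compounds named here, both results are summed up by the limit of > 2.41 h in this assay, at which 2 of the 2 values shown sit, so compound 1 stands where every value so far stands. Compound 3 `Nc1ncnc2c1c(Oc1cc(C(F)(F)F)ccn1)nn2C1CCC1` carries the change (cyclobutyl in place of 2-hydroxycyclohexyl on an aromatic nitrogen). Going by the values given here, no measured step guides this change, so the step from compound 1 to compound 3 is expected to be small, with an at least 1.2-fold lower number from compound 1 to compound 3 (0.08 log units; that floor lies within the scatter) estimated to stay within the usual scatter. Compound 3 is expected to give 2 h, between 0.8 h and 4 h.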

Compound 3, half-life: 1.02 h
Estimate against measurement, compound 3: 2.0-fold (0.29 log units) above; low and high end bracket the measured number.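

In this assay, this position on the aromatic nitrogen turns out to matter: cyclobutyl in place of 2-hydroxycyclohexyl gives an at least 2.3-fold lower number from compound 1 to compound 3 (0.37 log units; beyond the scatter). Compound 1 gives > 2.41 h, which is a limit of the assay and not a number. Compound 3 is the first compound here with a value that is not at that limit: the limit of > 2.41 h in this assay, at which 2 of the 3 values shown sit.

Left open is whether the lost hydroxy group or the change in ring size carries this step, since both change at once. A plain cyclohexyl or an open chain such as isopropyl on that nitrogen would speak to that question.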